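Dropping a Chloro Group from Compound 1

This account rests on a few compounds, and the source may have more. Where it says the series, first, only, none or still open, it means among the compounds named here.

Within the data shown here, compound 1, with the structure `CCCSc1nc(N/N=C(\C)c2ccccc2O)c2nnn(Cc3ccccc3Cl)c2n1`, is one of two compounds measured in a functional assay on MGC-803 cells (Homo sapiens) for antiproliferative activity, read by MTT assay, with a stated time of 72 h; on this read-out higher numbers stand for weaker inhibition and lower numbers for stronger inhibition. In this assay compound 1 gives 35000 nM, the higher of the two numbers recorded, which here means the weaker antiproliferative effect. The other measured compound, compound 2, has the structure `COc1cc(/C=N/Nc2nc(SCc3ccccc3)nc3c2nnn3Cc2ccccc2)cc(OC)c1OC` and differs from compound 1 in several places at once, so no single change can be read from it; in this assay compound 2 gives 1320 nM, a gap from compound 1 that lies well beyond the usual scatter.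

Compound 3, with the structure `CCCSc1nc(N/N=C(\C)c2ccccc2O)c2nnn(Cc3ccccc3)c2n1`, is not yet measured. It differs from compound 1 in one place: hydrogen in place of chloro on an aromatic carbon. The chloro group sits on a six-membered aromatic ring of carbon only, ortho to a large group, and is simply replaced by hydrogen.

Among the measured compounds shown here, no measured pair shows this change, so there is little to lean on. A step of this small kind is expected to stay near compound 1, and for compound 3 a step of a 1.1-fold higher number from compound 1 to compound 3 (0.06 log units; within the scatter) is estimated, likely no larger than the scatter in either direction. Compound 3 is therefore expected to give about 40000 nM in this assay, within a range from 12000 nM to 130000 nM.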

Compound 3, half-maximal inhibitory concentration: 2310 nM
Compound 3: middle estimate off by 17-fold (1.24 log units), on the high side; measured number below the stated range.
By their numbers in this assay, from the lowest: compounds 2 and 3 (each within the scatter of the next); then compound 1.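

Replacing the chloro group with hydrogen, which turns the 2-chlorobenzyl group into benzyl, gives a 15-fold lower number from compound 1 to compound 3 (1.18 log units; beyond the scatter) in this assay, so this place on the aromatic ring has a strong bearing on the result, even though the change is small on paper. Compounds 1 and 2 differ in several places at once and could not show this; here, with the rest of compound 1 left unchanged, the stronger inhibition can be tied to this one change. The compounds shown contain no measurement that explains the size of this step.

As far as these compounds go, it remains open whether fluoro, methyl or methoxy in this place would give a number closer to that of compound 1 or that of compound 3, and so whether chloro is unusual here or hydrogen is simply preferred. Compound 2 also carries a plain benzyl group, but it differs from compound 3 in other places as well, so the same swap on a different set of neighbouring groups cannot yet be judged.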